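Hexylamino for benzylsulfanyl on a fused aromatic core

The source may report more compounds than this note shows. Statements on the series, on what has been measured and on what is new or still open speak of the compounds shown alone.

Measured compounds:
compound 1, `CSc1nccc2c1ncn2[C@H]1C[C@H](O)[C@@H](CO)O1` — 36%
compound 2, `CC1OC(n2cnc3c(N)nccc32)CC1O` — 3%
compound 3, `OC[C@H]1OC(n2cnc3c(SCc4ccccc4)nccc32)[C@H](O)[C@@H]1O` — 30%

In a functional assay (Homo sapiens) for inhibition of Nucleic Acid, tested at 100 uM (a lower number here means less inhibition, a higher number more inhibition at the concentration tested (going by the name of the read-out)), compound 3 gives 30%, the second highest of the three numbers shown. Its nearest neighbour is compound 1, whose number is higher by an amount that lies within the scatter, so the two cannot be ordered. Compound 2 stands far lower, and that gap is beyond the scatter.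

The step from compound 3 to compound 4 is hexylamino in place of benzylsulfanyl on an aromatic carbon. Compound 4 has the structure `CCCCCCNc1nccc2c1ncn2C1O[C@H](CO)[C@@H](O)[C@H]1O`. Going by the values given here, no measured pair that differs only in this way is available, so the size of the step cannot be read from a neighbour. Compound 2 carries an amino group on the same core and gives 3%, but its sugar also differs, so it shows only that a nitrogen substituent can go with a low number. A modest downward step is expected, a number 5 percentage points lower from compound 3 to compound 4 (within the scatter), and it is estimated to stay within the scatter. Compound 4 is therefore expected to give 25%, in a range from 8% to 42% in this assay.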

Compound 4, a percentage reported as inhibition, at one concentration (the size of the read-out at that concentration, not a potency): 8%
Compound 4: the middle estimate sits 17 percentage points above what was measured, within the range that was stated.
By their numbers in this assay, from the lowest: compounds 2 and 4 (each within the scatter of the next); then compounds 3 and 1 (each within the scatter of the next).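

Within a single sugar series, the replacement of benzylsulfanyl by hexylamino on the aromatic carbon next to the ring nitrogen gives, in this assay, a number 22 percentage points lower from compound 3 to compound 4 (beyond the scatter) and so shows that the number responds to the group at this position. Compound 2 could not show this, since its sugar differs as well. The change removes the carbon-only aromatic ring and the sulfur and brings in an open chain with a nitrogen and a hydrogen-bond donor, and nothing available bears on why the number falls with this exchange.

This one pair cannot separate the sulfur-to-nitrogen exchange from the loss of the ring. Benzylamino and hexylsulfanyl at the same carbon would pull those two apart, and a shorter alkylamino chain would test the length of the hexyl group.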